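Extending a side chain on a weak adenosine receptor binder

The compounds below may be only part of what the source reports. "The series", "measured", "known", "first", "only" and "open" are said of these compounds alone.

Measured so far:
- compound 1 `CCCn1c(=O)c2c(ncn2C)n(C)c1=O`: 38000 nM
- compound 2 `C=CCn1c(=O)c2c(ncn2C)n(C)c1=O`: 47000 nM

In an assay on cell membranes with adenosine receptor A1 (Rattus norvegicus) as the target (on this read-out lower numbers stand for stronger inhibition and higher numbers for weaker inhibition), compound 1 gives 38000 nM and compound 2 gives 47000 nM. Among the compounds with values here, compound 2 stands highest of the two numbers, but its only neighbour is compound 1, and the step of a 1.2-fold higher number from compound 1 to compound 2 (0.09 log units; within the scatter) lies within the scatter, so the two cannot be told apart.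

Compound 3 `C=CCn1c(=O)c2c(ncn2C)n(CC=C)c1=O` differs from compound 2 by vinyl in place of hydrogen on a saturated chain carbon bound to an aromatic nitrogen. Within the data shown here, the single measured step, a 1.2-fold higher number from compound 1 to compound 2 (0.09 log units; within the scatter), swaps one chain for another at the same kind of place; it does not add a group where only hydrogen stood. It therefore bears only loosely on this change, and it was flat. The expected step of a 1.9-fold lower number from compound 2 to compound 3 (0.27 log units; within the scatter) for compound 3 is accordingly small, if anything towards a lower number, and not clearly beyond the scatter. Compound 3 is expected to give about 25000 nM in this assay, within 8000 nM to 80000 nM.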

Compound 3, inhibition constant: 18000 nM
For compound 3 the middle estimate is 1.4-fold (0.14 log units) above the measured one; low and high end bracket the measured number.
By their numbers in this assay, from the lowest: compound 3; then compounds 1 and 2 (each within the scatter of the next).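

Vinyl in place of hydrogen on a saturated chain carbon bound to an aromatic nitrogen, which turns methyl into allyl, gives a 2.6-fold lower number from compound 2 to compound 3 (0.42 log units; beyond the scatter) in this assay and so produces the first change in this small set that stands out from the noise. The earlier step, a 1.2-fold higher number from compound 1 to compound 2 (0.09 log units; within the scatter), could not show that, and the new one shows that this place does respond to a larger group, though only modestly, as compound 3 still gives 18000 nM as a weak binder. Nothing measured here explains why the number falls.

Going by these compounds, whether a longer chain or an amine at this place would lower the number further remains open. So does whether the gain needs the double bond of allyl or only the added carbons.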